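A few compounds are considered here, and "the series" means these few. Any claim that something is new, unique, unknown or untested is made for them only; others in the source may bear on it.

Compound 1 `O=c1[nH]cnc2c1c(-c1ccoc1)cn2[C@@H]1O[C@H](CO)[C@@H](O)[C@H]1O`: in a functional assay on K562 cells (Homo sapiens), read by MTT assay, with a stated time of 72 h (a higher number here means a weaker inhibitor, a lower number a stronger inhibitor), compound 1 gives 14500 nM.
Compound 2 `O=c1[nH]cnc2c1c(-c1cccs1)cn2[C@@H]1O[C@H](CO)[C@@H](O)[C@H]1O`: compound 2 reaches only the limit > 20000 nM, which is a limit of this assay and not a number.
Compound 3 `CSc1ncnc2c1c(-c1ccoc1)cn2[C@@H]1O[C@H](CO)[C@@H](O)[C@H]1O`: compound 3 gives 3250 nM, the lowest of the two numbers here.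

From compound 1 to compound 2 the change is thiophen-2-yl in place of furan-3-yl on an aromatic carbon, and it brings an at least 1.3-fold higher number from compound 1 to compound 2 (0.13 log units; that floor lies within the scatter). The true size of that step is hidden, because compound 2 sits at the limit of > 20000 nM in this assay, at which 1 of the 3 values shown sits.

The core of compound 3 differs from the core of compound 1, but that difference is not broken down here; what the values show is that compound 3 sits well below compound 1.

Compound 4 `CSc1ncnc2c1c(-c1cccs1)cn2[C@@H]1O[C@H](CO)[C@@H](O)[C@H]1O` carries the same change made on compound 3: thiophen-2-yl in place of furan-3-yl on an aromatic carbon. Since the surroundings of the change are the same in both pairs, the step is expected to look like the one already seen, so from compound 3 to compound 4 a rise of roughly a 2.0-fold higher number from compound 3 to compound 4 (0.30 log units; within the scatter) is estimated, resting on an at least 1.3-fold higher number from compound 1 to compound 2 (0.13 log units; that floor lies within the scatter). Compound 4 is therefore expected to give about 6500 nM, between 2500 nM and 20000 nM.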

Compound 4, half-maximal inhibitory concentration: > 20000 nM
Compound 4: no number, only a limit; the forecaster's own chance of this, stated with the estimate: 20%; middle value at least 3.0-fold (0.48 log units) from the limit.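

In this assay, placing thiophen-2-yl in place of furan-3-yl on the core of compound 3 brings an at least 6.1-fold higher number from compound 3 to compound 4 (0.78 log units; beyond the scatter). Compound 4 reaches only > 20000 nM, which is a limit of the assay and not a number, so this step gives a floor and its true size stays hidden. The result shows that on this core the change costs clearly more than the scatter, but it does not show whether the change has the same size on both cores: the same change on two cores in this assay, an at least 1.3-fold higher number (0.13 log units; that floor lies within the scatter) from compound 1 to compound 2 and an at least 6.1-fold higher number (0.78 log units; beyond the scatter) from compound 3 to compound 4; the limit leaves it open whether they differ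

The compounds shown leave open how other five-membered aromatic rings at this place, such as furan-2-yl or thiophen-3-yl, or a six-membered ring such as phenyl, would read in this assay. They also leave open whether an amine or a methoxy group in place of the methylthio group of compound 3 would keep the lower number seen for that compound.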